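The source may report more compounds than this note shows. Statements on the series, on what has been measured and on what is new or still open speak of the compounds shown alone.

Compounds measured so far:

Compound 1, `COC(=O)Cn1nc2c(n1)C(=O)C(C)=C(C)C2=O`: in a functional assay on KB cells (Homo sapiens) for inhibition, read by colorimetric assay, with a stated time of 72 h (on this read-out higher numbers stand for an effect only at larger amounts of compound and lower numbers for an effect already at smaller amounts), compound 1 gives 4 ug/mL.
Compound 2, `COC(=O)Cn1nc2c(n1)C(=O)C(C)=CC2=O`: compound 2 gives 1.5 ug/mL.
Compound 3, `COC(=O)C(C)n1n[n+]([O-])c2cc(C)c(C)cc21`: compound 3 gives > 100 ug/mL, which is a limit of the assay rather than a number.

Among the two numbers that are not limits, compound 1 stands highest; its nearest neighbour is compound 2, and the step between them is a 2.7-fold lower number from compound 1 to compound 2 (0.43 log units; beyond the scatter). The third value shown, that of compound 3, sits at the limit of > 100 ug/mL in this assay, at which 1 of the 3 values shown sits.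

The step followed here leads from compound 1 to compound 4, `CC1=C(C)C(=O)c2nn(C)nc2C1=O`. The change is hydrogen in place of methoxycarbonyl on a saturated chain carbon bound to an aromatic nitrogen. For the measured compounds named here, no measured step touches this place: the only measured step, from compound 1 to compound 2, swaps a methyl for a hydrogen on a double-bonded ring carbon and was modest. Going by the values given here, the (methoxycarbonyl)methyl to methyl change on the nitrogen has no counterpart in the data, so the expectation is a step of no change at the digits printed from compound 1 to compound 4 (within the scatter), which would keep compound 4 close to compound 1 and not beyond the scatter. Compound 4 is therefore estimated at 4 ug/mL, with a range from 1.3 ug/mL to 12 ug/mL.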

Compound 4, concentration for half-maximal effect: 3 ug/mL
For compound 4 the middle estimate is 1.3-fold (0.12 log units) above the measured one; low and high end bracket the measured number.
By their numbers in this assay, from the lowest: compounds 2, 4 and 1 (each within the scatter of the next, the first and the last beyond it). At a limit, above all of these: compound 3.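

In this assay, for the compounds shown here, the change from (methoxycarbonyl)methyl to methyl gives a 1.3-fold lower number from compound 1 to compound 4 (0.12 log units; within the scatter) and is the first measured change on this saturated chain carbon bound to an aromatic nitrogen. Removing the whole methoxycarbonyl group therefore leaves the read-out within the scatter, so on the core of compound 1 this group is not needed for the effect on these cells. Nothing in the data shown accounts for this result.

From the compounds shown here alone, at this place only the methoxycarbonyl group and hydrogen can be compared, so it remains open whether a carboxylic acid, an amine or a longer chain would also leave the number unchanged. Going by these compounds, it is also open whether this change would behave the same way on the core of compound 2, which keeps the methoxycarbonyl group.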